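A few compounds are considered here, and "the series" means these few. Any claim that something is new, unique, unknown or untested is made for them only; others in the source may bear on it.

Values so far in a functional assay on SNU-638 cells (Homo sapiens) for antiproliferative activity, read by sulforhodamine B assay, with a stated time of 72 h (a higher number here means a weaker inhibitor, a lower number a stronger inhibitor), are these.
- compound 1 `COc1ncc(-c2ccc3ncnc(NCCN(C)C)c3c2)cc1NS(=O)(=O)c1ccc(F)cc1` gives 1210 nM 
- compound 2 `CCCCS(=O)(=O)Nc1cc(-c2ccc3ncnc(NCc4ccncc4)c3c2)cnc1OC` gives 6660 nM 
- compound 3 `COc1ncc(-c2ccc3ncnc(NCc4ccncc4)c3c2)cc1NS(=O)(=O)c1ccc(F)cc1F` gives 6210 nM 

Compound 3 stands level with compound 2 at the upper end of these numbers, while compound 1 lies beyond the scatter from it on the lower side.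

Compound 4 `COc1ncc(-c2ccc3ncnc(NCCCN(C)C)c3c2)cc1NS(=O)(=O)c1ccc(F)cc1F` is reached from compound 3 by 2-(dimethylamino)ethyl in place of pyridin-4-yl on a saturated chain carbon bound to a nitrogen on an aromatic ring.

Going by the values given here, the only measured step, a 1.1-fold lower number from compound 2 to compound 3 (0.03 log units; within the scatter), lies at the sulfonyl sulfur and does not touch this place. The nearest guide is compound 1 (1210 nM), which carries 2-(dimethylamino)ethyl on that nitrogen but also differs from compound 4 in its chain and its sulfonyl group. On that single comparison, a move to a lower number beyond the scatter is expected in this assay, and the expected size is a 3.5-fold lower number from compound 3 to compound 4 (0.54 log units; beyond the scatter) for this change. The estimate for compound 4 is 1800 nM, with an expected range (600 nM to 5000 nM).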

Compound 4, half-maximal inhibitory concentration: 1260 nM
Beside the measured number, compound 4's estimate is 1.4-fold (0.15 log units) above it; the measured number falls inside the stated range.
By their numbers in this assay, from the lowest: compounds 1 and 4 (each within the scatter of the next); then compounds 3 and 2 (each within the scatter of the next).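

With the 2,4-difluorophenyl group on the sulfonyl sulfur held fixed, 3-(dimethylamino)propyl in place of (pyridin-4-yl)methyl gives a 4.9-fold lower number from compound 3 to compound 4 (0.69 log units; beyond the scatter) in this assay. Going by these compounds alone, this is the first measured step beyond the scatter, and it places the sensitivity at the amino substituent, whereas the step at the sulfonyl sulfur, a 1.1-fold lower number from compound 2 to compound 3 (0.03 log units; within the scatter), stays within the scatter. Because the change removes the aromatic ring and brings in an open chain ending in a dimethylamino group in one move, this single pair cannot separate the two. No supporting data bear on why the number falls.

As far as these compounds go, whether 3-(morpholin-4-yl)propyl in place of 3-(dimethylamino)propyl gives a similar step stays open. The compounds shown also hold no pair that isolates chain length from the sulfonyl group.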